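The source may report more compounds than this note shows. Statements on the series, on what has been measured and on what is new or still open speak of the compounds shown alone.

Measured in a functional assay on COR-L23 cells (Homo sapiens) for antiproliferative activity, read by CellTiter-Glo, with a stated time of 72 h (on this read-out higher numbers stand for weaker inhibition and lower numbers for stronger inhibition), so far:
- Compound 1 `CCC(=O)N[C@@H](C)c1ccc(NC(=O)N2CC(c3cccnc3)C2)cc1` gives 120 nM
- Compound 2 `C[C@H](NC(=O)c1ncccn1)c1ccc(NC(=O)N2CC(c3ccc(N)nc3)C2)cc1` gives 160 nM

The two numbers lie within the usual scatter of repeated measurements, so compound 2 cannot be told apart from compound 1 here. Compound 3 `CCC(=O)N[C@@H](C)c1ccc(NC(=O)N2CC(c3ccc(N)nc3)C2)cc1` keeps the rest of compound 2 and differs in one place: ethyl in place of pyrimidin-2-yl on a carbonyl carbon with ethyl in place of pyrimidin-2-yl on a carbonyl carbon. Going by the values given here, no measured pair shows this change alone. Among the compounds with values here, the only guide is compound 1, which also carries propanoylamino and gives 120 nM in this assay with a different group elsewhere. The expected 1.2-fold lower number from compound 2 to compound 3 (0.09 log units; within the scatter) is therefore none beyond the scatter, in either direction. For compound 3 the estimate is 130 nM as a middle value, with 40 nM to 420 nM as the expected range.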

Compound 3, half-maximal inhibitory concentration: 120 nM
The estimate for compound 3 lay 1.1-fold (0.03 log units) above the measured number; low and high end bracket the measured number.
By their numbers in this assay, from the lowest: compounds 1, 3 and 2 (each within the scatter of the next).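

In this assay, ethyl in place of pyrimidin-2-yl on the carbonyl carbon gives a 1.3-fold lower number from compound 2 to compound 3 (0.12 log units; within the scatter) and shows that, in this pair, a small chain and an aromatic ring at this position cannot be told apart. Amino in place of hydrogen on an aromatic carbon gives no change at the digits printed from compound 1 to compound 3 (within the scatter) and likewise has no readable effect in this pair. Nothing available here explains either result. Going by these compounds, how a longer chain or a carboxylic acid on this carbonyl carbon would behave remains open.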